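A Cyclohexyloxy Analogue Weighed Against Its Amine Parent

A few compounds are considered here, and "the series" means these few. Any claim that something is new, unique, unknown or untested is made for them only; others in the source may bear on it.

Compound 1, `N#Cc1ccc(Nc2nccc(NC3CCCC3)n2)cc1`, gives 9130 nM in an ADME assay on MT4 cells (Homo sapiens) for cytotoxicity, read by MTT assay; a lower number here means that less compound is tolerated, a higher number that more compound is tolerated.
Compound 2, `N#Cc1ccc(Nc2nccc(NC3CC3)n2)cc1`, gives 1190 nM in this assay.
Compound 3, `Cc1cc(NC2CCCCC2)nc(Nc2ccc(C#N)cc2)n1`, gives 340 nM in this assay.

Compound 3 holds the lowest of the three numbers; compound 2 stands nearest to it and compound 1 furthest. Compound 4, `Cc1cc(OC2CCCCC2)nc(Nc2ccc(C#N)cc2)n1`, differs from compound 3 in one place: cyclohexyloxy in place of cyclohexylamino on an aromatic carbon. For the measured compounds named here, the single measured step, a 7.7-fold lower number from compound 1 to compound 2 (0.88 log units; beyond the scatter), concerns the size of a ring on a nitrogen and says nothing about exchanging that nitrogen for an oxygen, so no step directly informs this change. Compound 4 is therefore expected to stay close to compound 3, with a step of a 1.5-fold higher number from compound 3 to compound 4 (0.17 log units; within the scatter) in this assay. The estimate for compound 4 is 500 nM, with a range of 150 nM to 2000 nM.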

Compound 4, half-maximal cytotoxic concentration: 320 nM
The estimate for compound 4 lay 1.6-fold (0.19 log units) above the measured number, and the stated range covers the measured number.
By their numbers in this assay, from the lowest: compounds 4 and 3 (each within the scatter of the next); then compound 2; then compound 1.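

In this assay, cyclohexyloxy in place of cyclohexylamino on this aromatic carbon gives a 1.1-fold lower number from compound 3 to compound 4 (0.03 log units; within the scatter) and so leaves compound 3 and compound 4 indistinguishable. The earlier step varied only the ring on the nitrogen, whereas this pair shows that the linking atom can be oxygen, without the hydrogen-bond donor of cyclohexylamino, and the numbers still read alike. Nothing measured here explains this result.

From the compounds shown here alone, whether the exchange would read the same with the cyclopentyl or cyclopropyl ring, or without the methyl group, remains open. So does how a sulfur or methylene link would read at this position.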